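Aryl versus isobutyl on the core: permeability notes

The source may report more compounds than this note shows. Statements on the series, on what has been measured and on what is new or still open speak of the compounds shown alone.

Compound 2 `COc1cccc(CNCCCNc2ccnc3cc(CC(C)C)ccc23)c1O` stands lowest of the two numbers in an ADME assay for permeability, using PAMPA, with a stated time of 30 min, at pH 7.4 (on this read-out lower numbers stand for lower permeability and higher numbers for higher permeability), where compound 2 gives 23 10^-6 cm/s. Among the measured compounds shown here, its only neighbour is compound 1 `COc1cccc(CNCCCNc2ccnc3cc(-c4ccc(F)cc4)ccc23)c1O`, which in this assay gives 237 10^-6 cm/s. For the measured compounds named here, the single step measured so far runs a 10-fold lower number from compound 1 to compound 2 (1.01 log units; beyond the scatter). Compound 3 `COc1cccc(CNCCCNc2ccnc3cc(-c4ccccc4)ccc23)c1O` has not yet been measured; its change from compound 2 is phenyl in place of isobutyl on an aromatic carbon. This change runs in kind opposite to the measured step: a six-membered aromatic ring of carbon only enters where isobutyl leaves, as in compound 1, though compound 3 lacks the fluorine of compound 1. The step from compound 1 to compound 2 therefore bears on it, and a step of comparable size is expected in the opposite direction, back toward the number of compound 1. Compound 3 is accordingly expected to give 180 10^-6 cm/s in this assay, with a range of 70 10^-6 cm/s to 400 10^-6 cm/s, which means an estimated step of a 7.8-fold higher number from compound 2 to compound 3 (0.89 log units; beyond the scatter). Going by the values given here, the range is kept wide because a 10-fold lower number from compound 1 to compound 2 (1.01 log units; beyond the scatter) is the only step available and compound 3 lacks the fluorine of compound 1.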

Compound 3, apparent permeability: 237 10^-6 cm/s
For compound 3 the middle estimate is 1.3-fold (0.12 log units) below the measured one, within the range that was stated.
By their numbers in this assay, from the lowest: compound 2; then compounds 1 and 3 (each within the scatter of the next).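

With the second aromatic compound in hand, the large gap to the isobutyl compound no longer rests on a single pair: in this assay phenyl in place of isobutyl on this aromatic carbon gives a 10-fold higher number from compound 2 to compound 3 (1.01 log units; beyond the scatter), the same size as the earlier step between the 4-fluorophenyl and isobutyl compounds, read in the opposite direction. The fluorine turns out not to be required for the higher number, since hydrogen in place of fluoro gives no change at the digits printed from compound 1 to compound 3 (within the scatter), so at this position the read-out separates the two aromatic substituents from isobutyl and does not separate them from each other. No measured evidence is at hand to explain the difference between phenyl and isobutyl.

Open, on these data alone, is whether the number in this assay stays near that of compound 3 when the phenyl ring carries an amine or a carboxylic acid in place of the hydrogen or fluorine seen so far. Also open, as far as these compounds go, is where a longer alkyl chain or a saturated cyclohexyl ring would fall relative to compound 2 and compound 3, which would show whether the aromatic ring itself or only the size of the substituent tracks with the read-out.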